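From methyl to hydrogen on an aromatic nitrogen

This account rests on a few compounds, and the source may have more. Where it says the series, first, only, none or still open, it means among the compounds named here.

Within the data shown here, in a functional assay on MCF7 cells (Homo sapiens) for cytotoxicity, read by MTT assay, with stated times of 6 h and 48 h (on this read-out higher numbers stand for weaker inhibition and lower numbers for stronger inhibition), compound 1 (`COc1ccc(OC)c(C(=O)/C=C/c2cc(Br)c(Br)n2C)c1`) gives 650 nM and stands lowest of the two numbers so far. Compound 2 (`Cn1c(/C=C/C(=O)c2cccc(N)c2)cc(Br)c1Br`) lies beyond the scatter from it, with a higher reading (12400 nM). Compound 3 (`COc1ccc(OC)c(C(=O)/C=C/c2cc(Br)c(Br)[nH]2)c1`) has not yet been measured and differs from compound 1 by hydrogen in place of methyl on an aromatic nitrogen. Among the measured compounds shown here, no measured pair shows this change, so the expectation is loose. A modest rise in the number (a 1.8-fold higher number from compound 1 to compound 3 (0.27 log units; within the scatter)) is expected in this assay as the likeliest outcome. Compound 3 is estimated at 1200 nM (expected range 300 nM to 5000 nM).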

Compound 3, half-maximal inhibitory concentration: 220 nM
Estimate against measurement, compound 3: 5.5-fold (0.74 log units) above; measured number outside the range, below it.
By their numbers in this assay, from the lowest: compound 3; then compound 1; then compound 2.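

The methyl on the aromatic nitrogen is not needed for the activity of compound 1: in this assay, replacing it with hydrogen gives (a 3.0-fold lower number from compound 1 to compound 3 (0.47 log units; beyond the scatter)). This position therefore responds to even the smallest change, and removing this one carbon lowers the number rather than raising it. No accompanying measurement offers an explanation for this step.

From the compounds shown here alone, an ethyl group or a longer chain on this nitrogen could extend the picture in either direction, and that remains open. Going by these compounds, whether the same change gives a similar step on compound 2 also remains open.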